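The compounds below may be only part of what the source reports. "The series", "measured", "known", "first", "only" and "open" are said of these compounds alone.

Three compounds have been measured in an assay on isolated protein for inhibition of 2-Hydroxyacid oxidase 2 (Homo sapiens), tested at 10 uM; a higher number here means a stronger effect of the compound at the concentration tested, a lower number a weaker effect:

compound 1 `Cc1n[nH]c(C(=O)O)c1Cc1cccc(-c2cccc(F)c2)c1`: 50%
compound 2 `Cc1n[nH]c(C(=O)O)c1Cc1cccc(-c2ccc(C#N)cc2)c1`: 46%
compound 3 `Cc1n[nH]c(C(=O)O)c1Cc1cccc(C(N)=O)c1`: 8%

Compound 3 stands lowest of the three, as the steps of a number 42 percentage points lower from compound 1 to compound 3 (beyond the scatter) and a number 38 percentage points lower from compound 2 to compound 3 (beyond the scatter) show, while compound 1 and compound 2 lie within the scatter of each other, a number 4 percentage points lower from compound 1 to compound 2 (within the scatter). Compound 4 `Cc1n[nH]c(C(=O)O)c1Cc1cccc(C#N)c1` differs from compound 3 by cyano in place of carbamoyl on an aromatic carbon. Going by the values given here, no measured step exchanges one small group for another at this position; both large steps replace the carbamoyl with a biaryl group, so they say nothing direct about a cyano. Compound 4 is therefore expected to stay near compound 3, with a small and uncertain step a number 7 percentage points higher from compound 3 to compound 4 (within the scatter), estimated at 15% within a range of 0% to 40%.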

Compound 4, a percentage reported as inhibition, at one concentration (the size of the read-out at that concentration, not a potency): 19%
Compound 4: middle estimate off by 4 percentage points, on the low side; low and high end bracket the measured number.
By their numbers in this assay, from the lowest: compound 3; then compound 4; then compounds 2 and 1 (each within the scatter of the next).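

In this assay the two small groups at this aromatic carbon do not read alike: the change to cyano, which leaves out the hydrogen-bond donor of the carbamoyl, gives a number 11 percentage points higher from compound 3 to compound 4 (beyond the scatter). Even so, the small cyano closes only part of the gap to the aryl groups, with a number 27 percentage points lower from compound 2 to compound 4 (beyond the scatter) and a number 31 percentage points lower from compound 1 to compound 4 (beyond the scatter). Nothing available explains either difference. Where an amine or a methoxy group would fall among the small groups stays open, as does whether an unsubstituted phenyl would match the two substituted phenyl groups.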